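The source may hold more compounds than are shown below. What is called first, only, known or untested is meant among the compounds shown, and "the series" means these compounds.

Measured so far:
compound 1, `O=C(Nc1ccccc1)c1ccc(C(=O)O)nc1`, 26500 nM in an assay on isolated protein (Gallus gallus) for inhibition of transmembrane prolyl 4-hydroxylase (Homo sapiens); a lower number here means a stronger inhibitor, a higher number a weaker inhibitor
compound 2, `O=C(Nc1ccccc1Cl)c1ccc(C(=O)O)nc1`, 16300 nM in this assay

In this assay, among the compounds with values here, compound 2 gives 16300 nM, and the only other number at hand is that of compound 1, which gives 26500 nM. The two stand close together: the step of a 1.6-fold lower number from compound 1 to compound 2 (0.21 log units; within the scatter) did not move the number beyond the usual scatter, so neither compound can be called the stronger inhibitor on these data.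

Compound 3, `O=C(Nc1ccccc1F)c1ccc(C(=O)O)nc1`, differs from compound 2 in one place: fluoro in place of chloro on an aromatic carbon. Within the data shown here, only one measured step bears on this change, the step from hydrogen to chloro at the same aromatic carbon, a 1.6-fold lower number from compound 1 to compound 2 (0.21 log units; within the scatter), which stayed within the scatter. A second exchange of one halogen for another at that carbon is therefore not expected to produce a step beyond the scatter in this assay in either direction.

Compound 3 is accordingly expected to give about 20000 nM in this assay, with a range from 8000 nM to 50000 nM. That estimate means a step of a 1.2-fold higher number from compound 2 to compound 3 (0.09 log units; within the scatter).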

Compound 3, half-maximal inhibitory concentration: 11000 nM
The estimate for compound 3 lay 1.8-fold (0.26 log units) above the measured number; the range from low to high includes it.
By their numbers in this assay, from the lowest: compounds 3, 2 and 1 (each within the scatter of the next, the first and the last beyond it).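

At the aromatic carbon ortho to a large group, the result shows that in this assay the exchange of one halogen for the other gives a 1.5-fold lower number from compound 2 to compound 3 (0.17 log units; within the scatter) and so does not separate chloro from fluoro on these data. Fluoro in place of hydrogen at that carbon gives a 2.4-fold lower number from compound 1 to compound 3 (0.38 log units; beyond the scatter) and is the only single change at this position among the three compounds to pass beyond the scatter, though only modestly, so a halogen here can shift the number to a small degree without either halogen standing apart from the other. No measurement is at hand that would explain this small shift or tie it to any property of the two halogens.

The compounds shown leave open whether a methyl, methoxy or trifluoromethyl group, or an amine, on this same carbon would move the number further in either direction than fluoro does. They also leave open whether fluoro or chloro on another carbon of the same ring would give a similar step, and whether any such step would hold if the carboxylic acid of the shared core were replaced by an ester or a tetrazole.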